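Swapping a chlorophenyl for cyclobutyl on a thioether arm

The source may hold more compounds than are shown below. What is called first, only, known or untested is meant among the compounds shown, and "the series" means these compounds.

Compound 1 `CCc1ccccc1Nc1nc(Cl)nc(Cl)n1`: -2.26%
Compound 2 `Clc1nc(Cl)nc(Nc2ccccc2Br)n1`: 4.52%
Compound 3 `O=c1nc(SCc2ccccc2)nc(SCc2ccc(Cl)cc2)[nH]1`: 6.91%

Of the compounds shown here, three have been tested in an assay for inhibition of Pro-cathepsin H (Homo sapiens), read by fluorescence, tested at 50 uM; a higher number here means more inhibition at the concentration tested (going by the name of the read-out), a lower number less inhibition. Compound 1 and compound 2 share one core, and compound 3 carries a different core with two benzylic thioether arms. In this assay compound 3 gives 6.91%, a number that lies within the usual scatter of the value of compound 2 and of the value of compound 1; none of the three numbers is separated from the others by more than the scatter.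

Compound 4 `O=c1nc(SCc2ccccc2)nc(SCC2CCC2)[nH]1` is not yet measured. It differs from compound 3 in one place: cyclobutyl in place of 4-chlorophenyl on a saturated chain carbon bound to a sulfur. Among the measured compounds shown here, the only measured step, a number 6.8 percentage points higher from compound 1 to compound 2 (within the scatter), concerns a different core and a different kind of change, so it gives no direct guide here. What the three values do show is that this assay has so far reported only small inhibition for every compound, whatever the core or the substituent.

On that basis compound 4 is expected to stay in the same low band, with a step from compound 3 of a number 1.9 percentage points lower from compound 3 to compound 4 (within the scatter), which is not beyond the scatter. Compound 4 is therefore estimated at 5%, with a range from -8% to 18%.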

Compound 4, a percentage reported as inhibition, at one concentration (the size of the read-out at that concentration, not a potency): 1.57%
Compound 4: the middle estimate sits 3.4 percentage points above what was measured; measured number inside the range.
By their numbers in this assay, from the lowest: compounds 1, 4, 2 and 3 (each within the scatter of the next).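

In this assay, cyclobutyl in place of 4-chlorophenyl on a saturated chain carbon bound to a sulfur gives a number 5.3 percentage points lower from compound 3 to compound 4 (within the scatter), the only reading shown for this position on the core of compound 3. The arm can therefore give up its six-membered aromatic ring and its chlorine for a four-membered non-aromatic ring of carbon only with no change that this assay can separate from its scatter, and compound 4, at 1.57%, stays in the same low band as compound 3, a point the step between compound 1 and compound 2, on a different core, could not settle. No evidence is at hand that bears on this step, and the numbers alone offer no account of it.

The compounds shown leave open whether an amine, a carboxylic acid or a longer chain at this place on the thioether arm would lift the number in this assay clear of the scatter. Among the compounds shown here, they also leave open what a change in the other thioether arm, the one compound 3 and compound 4 share, would do, for instance a pyridine ring in place of its phenyl ring.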